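A Second Bromo on a Saturated Ring Carbon

This account rests on a few compounds, and the source may have more. Where it says the series, first, only, none or still open, it means among the compounds named here.

Measured in a physicochemical assay for metabolic stability (on this read-out lower numbers stand for a shorter-lived compound and higher numbers for a longer-lived compound), so far:
Compound 1 `Cc1cccc(C(=O)n2ncc3c2CCCC3=O)c1` gives 1.64 h 
Compound 2 `O=C1c2cn(C(=O)C3CC3)nc2CCC1Br` gives 1.91 h 
Compound 3 `O=C1c2cnn(C(=O)C3CC3)c2CCC1Br` gives 3.91 h 

Compound 3 has the highest number of the three at 3.91 h and stands beyond the scatter from both compound 2 and compound 1. Compound 4 `O=C(C1CC1)n1ncc2c1CCC(Br)(Br)C2=O` is still unmeasured. It differs from compound 3 by the change bromo in place of hydrogen on a saturated ring carbon.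

Among the measured compounds shown here, no two measured compounds differ in only one place, so the data give no direct guide to the size of this change. With that gap stated plainly, no shift beyond the scatter is expected in this assay, though a slightly lower number seems more likely than a higher one. The expected change, a 1.3-fold lower number from compound 3 to compound 4 (0.12 log units; within the scatter), is only an estimate and starts from compound 3 at 3.91 h on the same read-out. In this assay compound 4 is estimated at 3 h with an expected range of 1.2 h to 7 h for its measurement.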

Compound 4, half-life: 0.952 h
Estimate against measurement, compound 4: 3.2-fold (0.50 log units) above; measured number below the stated range.
By their numbers in this assay, from the lowest: compounds 4, 1 and 2 (each within the scatter of the next); then compound 3.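

In this assay, among the compounds shown here, a second bromo on a saturated ring carbon gives a 4.1-fold lower number from compound 3 to compound 4 (0.61 log units; beyond the scatter), a step beyond the scatter and the first comparison that isolates a single change. It shows that this position is not indifferent to substitution: placing bromo in place of the hydrogen there yields a shorter-lived compound. Nothing available bears on why the number falls, so the result stands as an observation without an explanation.

The compounds shown leave open whether this drop belongs to bromo specifically or would also follow another group in the same place, such as fluoro, methyl or an amine. They also leave open whether the step would hold on a different core, as it rests on this one pair alone.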